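The source may report more compounds than this note shows. Statements on the series, on what has been measured and on what is new or still open speak of the compounds shown alone.

Compound 1 `COc1ccc(-c2c(-c3ccc(OC)cc3)n(Cc3ccccc3)c3ncn(CCCO)c(=N)c23)cc1` was examined in an ADME assay for permeability, using PAMPA, with a stated time of 30 min, at pH 7.4; on this read-out higher numbers stand for higher permeability and lower numbers for lower permeability. In this assay compound 1 gives > 1000 10^-6 cm/s, which is a limit of the assay rather than a number. Compound 1 thus stands at the limit of > 1000 10^-6 cm/s in this assay, at which 1 of the 3 values shown sits. Compound 2 `COc1ccc(Cn2c(-c3ccccc3)c(-c3ccccc3)c3c(=N)n(CC4CCOCC4)cnc32)cc1` gives 1270 10^-6 cm/s in this assay, and compound 3 `Cc1c(C)n(Cc2ccccc2)c2ncn(CCCO)c(=N)c12` gives 609 10^-6 cm/s. Compound 4 `COc1ccc(-c2c(-c3ccc(OC)cc3)n(Cc3ccccc3)c3ncn([C@@H]4CCCC[C@H]4O)c(=N)c23)cc1` differs from compound 1 by 2-hydroxycyclohexyl in place of 3-hydroxypropyl on an aromatic nitrogen. For the measured compounds named here, no step between two measured compounds is available here to guide the size of this change. With compound 1 already at the limit, the step expected is a step that the limit leaves unreadable from compound 1 to compound 4, none beyond the scatter. Compound 4 is therefore expected to give 1100 10^-6 cm/s in this assay, within a range from 500 10^-6 cm/s to 2200 10^-6 cm/s.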

Compound 4, apparent permeability: > 1000 10^-6 cm/s
Compound 4 gave a limit, no number; the forecaster's own chance of this, stated with the estimate: 55%; the middle value is on the limit's open side.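

Compound 1 and compound 4 both give a limit of the assay rather than a number, so no step between them can be read: the limit of > 1000 10^-6 cm/s in this assay, at which 2 of the 4 values shown sit.

The compounds shown leave open whether 2-hydroxycyclohexyl in place of 3-hydroxypropyl on an aromatic nitrogen changes the value in this assay at all.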